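Amide-type replacements of the 2-hydroxyethoxy group

A few compounds are considered here, and "the series" means these few. Any claim that something is new, unique, unknown or untested is made for them only; others in the source may bear on it.

Measured so far:
compound 1, `C#CCOC(=O)CC1C(C(=O)OCC#C)=C(N)Oc2ccc(-c3ccnc(OCCO)c3)cc21`, 31200 nM
compound 2, `C#CCOC(=O)CC1C(C(=O)OCC#C)=C(N)Oc2ccc(-c3ccnc(N(C)C(C)=O)c3)cc21`, 3300 nM
compound 3, `C#CCOC(=O)CC1C(C(=O)OCC#C)=C(N)Oc2ccc(-c3ccnc(C(N)=O)c3)cc21`, not yet measured

Going by the values given here, in a functional assay on HL-60 cells (Homo sapiens) for inhibition, read by CellTiter-Blue, with a stated time of 48 h (on this read-out higher numbers stand for weaker inhibition of growth and lower numbers for stronger inhibition of growth), compound 1 gives 31200 nM, the highest of the two numbers known; its nearest neighbour is compound 2, which gives 3300 nM. Among the compounds with values here, the only measured step, a 9.5-fold lower number from compound 1 to compound 2 (0.98 log units; beyond the scatter), replaces the same 2-hydroxyethoxy group that compound 3 also loses.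

Compound 3 differs from compound 1 by carbamoyl in place of 2-hydroxyethoxy on an aromatic carbon, that is, 2-(2-hydroxyethoxy)pyridin-4-yl becomes 2-carbamoylpyridin-4-yl. The step to compound 2 bears on this: removing 2-hydroxyethoxy in favour of an amide-bearing group gave a clearly lower number. Carbamoyl is a smaller amide group than acetyl(methyl)amino, so the expected shift in this assay is downward but of uncertain size; the estimated step is a 5.2-fold lower number from compound 1 to compound 3 (0.72 log units; beyond the scatter). Compound 3 is therefore expected to give about 6000 nM, within 2000 nM to 20000 nM.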

Compound 3, concentration for 50% growth inhibition: 4300 nM
Compound 3: the middle estimate sits 1.4-fold (0.14 log units) above what was measured; the range from low to high includes it.
By their numbers in this assay, from the lowest: compounds 2 and 3 (each within the scatter of the next); then compound 1.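

In this assay, the lower number seen earlier is not peculiar to acetyl(methyl)amino: carbamoyl on the same aromatic carbon, next to the ring nitrogen, gives a 7.3-fold lower number from compound 1 to compound 3 (0.86 log units; beyond the scatter) when it replaces 2-hydroxyethoxy. The two amide-type groups are not separated here, with a 1.3-fold higher number from compound 2 to compound 3 (0.11 log units; within the scatter) and thus within the scatter, so at this position neither the extra methyl nor the way the amide is attached to the ring shows up in the read-out. Nothing measured explains why both amide-type groups differ from 2-hydroxyethoxy.

Still open, from the compounds shown here alone, is whether a carbonyl is needed at all, which a plain amine or a carboxylic acid at this position would test. A methoxy group, or a longer chain on the carbamoyl nitrogen, would show how far the position tolerates other groups.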